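This account rests on a few compounds, and the source may have more. Where it says the series, first, only, none or still open, it means among the compounds named here.

Measured so far in a functional assay on DLD-1 cells (Homo sapiens) for cytotoxicity, with a stated time of 48 h; a higher number here means a weaker inhibitor, a lower number a stronger inhibitor:

- Compound 1 `CCCCC(=O)Oc1ccc2oc(/C=C/[S+](C)[O-])cc(=O)c2c1`: 6700 nM
- Compound 2 `CC(C)Oc1ccc2oc(/C=C/[S+](C)[O-])cc(=O)c2c1`: 8000 nM

Compound 2, at 8000 nM, lies within the usual scatter of compound 1, so neither can be called the stronger inhibitor. The next compound, compound 3 `C[S+]([O-])/C=C/c1cc(=O)c2cc(Br)ccc2o1`, keeps the shared core and differs from compound 2 in one place: bromo in place of isopropoxy on an aromatic carbon. Put simply, it has bromo in place of isopropoxy on an aromatic carbon.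

Among the measured compounds shown here, only one measured step offers any guidance: a 1.2-fold higher number from compound 1 to compound 2 (0.08 log units; within the scatter). That step exchanged the group on the oxygen while the oxygen stayed in place, whereas compound 3 loses the whole isopropoxy group. For the measured compounds named here, no measured compound carries bromo, so the evidence is thin and gives no direction. Going by the values given here, the one small step is the only guide, so no change beyond the scatter is expected in this assay, although a wide margin is needed. The expected change is a 1.1-fold lower number from compound 2 to compound 3 (0.06 log units; within the scatter). Compound 3 is estimated at 7000 nM, with an expected range of 2500 nM to 20000 nM.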

Compound 3, half-maximal inhibitory concentration: 4500 nM
Beside the measured number, compound 3's estimate is 1.6-fold (0.19 log units) above it; low and high end bracket the measured number.
By their numbers in this assay, from the lowest: compounds 3, 1 and 2 (each within the scatter of the next).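

In this assay, the same aromatic carbon now carries a bromo group as well as two groups attached through oxygen, and the number stays within the scatter both times, with a 1.8-fold lower number from compound 2 to compound 3 (0.25 log units; within the scatter) and a 1.5-fold lower number from compound 1 to compound 3 (0.17 log units; within the scatter). The earlier pair changed only what sat on the oxygen, whereas compound 3 has no oxygen at this position: isopropoxy, with 4 heavy atoms and 1 hydrogen-bond acceptor, gives way to bromo, with 1 heavy atom and no acceptor, without a change beyond the scatter, so among these three compounds the oxygen link is not required for a number in this range. No measurement is available that could explain why these different groups give such similar numbers.

All three compounds lie within the scatter of one another, so no group at this position has yet been shown to shift the number clearly in either direction. As far as these compounds go, whether an amine, a carboxylic acid or a longer carbon chain on this aromatic carbon would shift it remains open, and so does the effect of changing any other part of the shared core.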